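Swapping a Halogenated Phenyl Arm on a Shared Core

The source may hold more compounds than are shown below. What is called first, only, known or untested is meant among the compounds shown, and "the series" means these compounds.

Of the compounds shown here, two on a shared core have been measured in a functional assay on UACC-62 cells (Homo sapiens) for inhibition, read by sulforhodamine B assay, with a stated time of 48 h, tested at 10 uM; a higher number here means more inhibition at the concentration tested (going by the name of the read-out), a lower number less inhibition. Compound 1 `O=Cc1ccc(-c2cn3ccnc3c(-c3ccc4ncn(C5CCCCC5)c4c3)n2)cc1` gives 37.1% in this assay, and compound 2 `Clc1ccc(-c2cn3ccnc3c(-c3ccc4ncn(C5CCCCC5)c4c3)n2)cc1` gives 30.5%. Within the data shown here, the one step between them, a number 6.6 percentage points lower from compound 1 to compound 2 (within the scatter), is chloro in place of formyl on an aromatic carbon. Compound 2 thus stands at the bottom of the two numbers shown, its only neighbour being compound 1, but the gap lies within the scatter, so the two cannot be told apart.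

Compound 3 `Fc1ccccc1-c1cn2ccnc2c(-c2ccc3ncn(C4CCCCC4)c3c2)n1` is not yet measured. It differs from compound 2 as follows: 2-fluorophenyl in place of 4-chlorophenyl on an aromatic carbon. Among the measured compounds shown here, only one measured step bears on this change, namely the step from compound 1 to compound 2, which also altered the phenyl arm on the same carbon and moved the read-out by an amount within the scatter. For the measured compounds named here, no measured pair exchanges a 4-chlorophenyl for a 2-fluorophenyl, so the data give no direction. Compound 3 is therefore expected to differ from compound 2 by a step of a number 0.5 percentage points lower from compound 2 to compound 3 (within the scatter), not beyond the scatter. The value of compound 3 in this assay is estimated at 30%, with a range from 15% to 45%.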

Compound 3, a percentage reported as inhibition, at one concentration (the size of the read-out at that concentration, not a potency): 38.2%
Estimate against measurement, compound 3: 8.2 percentage points below; measured number inside the range.
By their numbers in this assay, from the lowest: compounds 2, 1 and 3 (each within the scatter of the next).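

In this assay the exchange of 4-chlorophenyl for 2-fluorophenyl on this aromatic carbon gives a number 7.7 percentage points higher from compound 2 to compound 3 (within the scatter) and the exchange of 4-formylphenyl for 2-fluorophenyl gives a number 1.1 percentage points higher from compound 1 to compound 3 (within the scatter) for the same position. Three different phenyl arms have now been read at this carbon of the shared core, and none can be told apart from the others, so neither the change of halogen and its place on the phenyl ring nor the loss of the formyl group separates these compounds here. No measurement at hand offers a reason for these numbers.

The 2-fluorophenyl arm changes both the halogen and where it sits relative to 4-chlorophenyl, so these compounds cannot show what either change does alone. From the compounds shown here alone, it remains open whether a phenyl arm carrying an amine or a carboxylic acid, or a longer chain in place of the phenyl ring, would move the number beyond the scatter at this position.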